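Amine Swap at the Chain End: Estimating Compound 3

A few compounds are considered here, and "the series" means these few. Any claim that something is new, unique, unknown or untested is made for them only; others in the source may bear on it.

compound 1 `O=c1cc(-c2ccccc2)oc2c(OCCCN3CCCC3)c(OCc3ccccc3)cc(O)c12` — 2230 nM
compound 2 `CN(C)CCCCOc1c(OCc2ccccc2)cc(O)c2c(=O)cc(-c3ccccc3)oc12` — 3210 nM

In a functional assay on MCF7 cells (Homo sapiens) for cytotoxicity, read by MTT assay, with a stated time of 72 h (on this read-out lower numbers stand for stronger inhibition and higher numbers for weaker inhibition), compound 2 gives 3210 nM, the top of the two numbers recorded, though its gap to compound 1 lies within the scatter. Among the measured compounds shown here, the only measured step is a 1.4-fold higher number from compound 1 to compound 2 (0.16 log units; within the scatter), an exchange of one amine for another on the same chain. Compound 3 `CN1CCN(CCCCOc2c(OCc3ccccc3)cc(O)c3c(=O)cc(-c4ccccc4)oc23)CC1` carries the change (4-methylpiperazin-1-yl in place of dimethylamino on a saturated chain carbon, four bonds along the chain from an oxygen on an aromatic ring). For the measured compounds named here, since the one comparable amine swap stayed within the scatter, no step beyond the scatter is expected in this assay. Compound 3 is therefore estimated at 3500 nM, between 1500 nM and 8000 nM. The expected step is a 1.1-fold higher number from compound 2 to compound 3 (0.04 log units; within the scatter).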

Compound 3, half-maximal inhibitory concentration: 2930 nM
Compound 3: the middle estimate sits 1.2-fold (0.08 log units) above what was measured; measured number inside the range.
By their numbers in this assay, from the lowest: compounds 1, 3 and 2 (each within the scatter of the next).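

In this assay, 4-methylpiperazin-1-yl in place of dimethylamino gives a 1.1-fold lower number from compound 2 to compound 3 (0.04 log units; within the scatter) and so, at this place on the chain, a six-membered non-aromatic ring with 2 hetero atoms leaves the number within the scatter. The wider change, (4-methylpiperazin-1-yl)methyl in place of pyrrolidin-1-yl, gives a 1.3-fold higher number from compound 1 to compound 3 (0.12 log units; within the scatter) and also stays within the scatter. No measurement at hand bears on why these numbers stay so close.

The compounds shown leave open whether a primary amine or a carboxylic acid at the chain end would move the number beyond the scatter. They also leave open what a longer chain would do.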